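Stability of compound 3 after a side-chain swap

A few compounds are considered here, and "the series" means these few. Any claim that something is new, unique, unknown or untested is made for them only; others in the source may bear on it.

- Compound 1 `CCC(C)CCn1nc(-c2cccs2)c(O)c(C2=NS(=O)(=O)c3cc(NS(C)(=O)=O)ccc3N2)c1=O` gives > 1 h (a limit)
- Compound 2 `CC(C)Cn1nc(-c2cccs2)c(O)c(C2=NS(=O)(=O)c3cc(NS(C)(=O)=O)ccc3N2)c1=O` gives > 1 h (a limit)

Both entries are half-lives from an in vitro ADME assay on microsomes from liver (Homo sapiens) for metabolic stability, tested at 5 uM (a lower number here means that the compound disappears faster, a higher number that the compound lasts longer), and neither is an exact number. Compound 2 stands at > 1 h and that is a limit of the assay. Compound 3 `CS(=O)(=O)Nc1ccc2c(c1)S(=O)(=O)N=C(c1c(O)c(-c3cccs3)nn(CC3(C(F)(F)F)CCC3)c1=O)N2` carries 1-(trifluoromethyl)cyclobutyl in place of isopropyl on a saturated chain carbon bound to an aromatic nitrogen and has not yet been measured. Among the measured compounds shown here, the only measured change is a step that the two limits leave unreadable from compound 1 to compound 2 and it gives no size to carry forward. The evidence amounts to the limit of > 1 h in this assay, at which 2 of the 2 values shown sit, and so sets a floor rather than a trend. No step beyond the usual scatter can therefore be expected in this assay and no direction can be argued. The expected step is a step that the limit leaves unreadable from compound 2 to compound 3 (an estimate, not a reading). Compound 3 is estimated at 1.5 h (expected range 0.8 h to 3 h) and may itself be reported only as a limit.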

Compound 3, half-life: 1 h
Compound 3: middle estimate off by 1.5-fold (0.18 log units), on the high side, and the stated range covers the measured number.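

In this assay, among the compounds shown here, compound 3, with 1-(trifluoromethyl)cyclobutyl in place of isopropyl, gives 1 h, the first exact number at this position on a saturated chain carbon bound to an aromatic nitrogen, and this change gives a number no higher from compound 2 to compound 3 (the limit leaves the size open). With 1-(trifluoromethyl)cyclobutyl in place of 2-methylbutyl, the change gives a number no higher from compound 1 to compound 3 (the limit leaves the size open). Compound 1 and compound 2 are known only through a limit of the assay: the limit of > 1 h in this assay, at which 2 of the 3 values shown sit. The steps from each of them to compound 3 cannot be read in size, so the new value offers a fixed reference point for this position rather than a measured effect of the change.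

As far as these compounds go, how far compound 1 and compound 2 lie from compound 3 stays open, as does how much of the change belongs to the four-membered ring and how much to the trifluoromethyl. From the compounds shown here alone, a plain cyclobutyl or an amine at this position also remains unknown in this assay.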